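Replacing the Hydroxy Group of Compound 3 with Piperidin-1-yl

The source may hold more compounds than are shown below. What is called first, only, known or untested is meant among the compounds shown, and "the series" means these compounds.

Compound 3 `Cc1cc(O)c(S(C)(=O)=O)cc1C(=O)N=C(N)N` gives 220 nM in a functional assay for inhibition of sodium/hydrogen exchanger (Oryctolagus cuniculus) (on this read-out lower numbers stand for stronger inhibition and higher numbers for weaker inhibition), the highest number among the three measured compounds. Compound 1 `Cc1cc(-c2ccco2)c(S(C)(=O)=O)cc1C(=O)N=C(N)N` gives 16 nM and compound 2 `Cc1cc(OCc2ccccc2)c(S(C)(=O)=O)cc1C(=O)N=C(N)N` gives 28 nM; the steps of a 14-fold higher number from compound 1 to compound 3 (1.14 log units; beyond the scatter) and a 7.9-fold higher number from compound 2 to compound 3 (0.90 log units; beyond the scatter) set compound 3 apart from both beyond the scatter, whereas a 1.8-fold higher number from compound 1 to compound 2 (0.24 log units; within the scatter) stays within it.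

Compound 4 `Cc1cc(N2CCCCC2)c(S(C)(=O)=O)cc1C(=O)N=C(N)N` differs from compound 3 at one place: piperidin-1-yl in place of hydroxy on an aromatic carbon. Among the measured compounds shown here, the steps that bear on this change are the two in which hydroxy stands in place of a larger group at the same aromatic carbon: a 14-fold higher number from compound 1 to compound 3 (1.14 log units; beyond the scatter) and a 7.9-fold higher number from compound 2 to compound 3 (0.90 log units; beyond the scatter), one large and one modest, both raising the number. Piperidin-1-yl, like furan-2-yl, brings six heavy atoms and a ring in place of the single oxygen, so a lowering of the number beyond the scatter is expected when hydroxy is replaced. Compound 4 is therefore estimated at 30 nM, with a range from 10 nM to 100 nM. For compound 4 the expected step is a 7.3-fold lower number from compound 3 to compound 4 (0.87 log units; beyond the scatter).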

Compound 4, half-maximal inhibitory concentration: 21 nM
Compound 4: the middle estimate sits 1.4-fold (0.15 log units) above what was measured; low and high end bracket the measured number.
By their numbers in this assay, from the lowest: compounds 1, 4 and 2 (each within the scatter of the next); then compound 3.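

In this assay, the step of a 10-fold lower number from compound 3 to compound 4 (1.02 log units; beyond the scatter) shows that this aromatic carbon also accepts a non-aromatic ring, joined through its nitrogen, and not only the furan-2-yl and benzyloxy groups seen earlier. The steps of a 1.3-fold lower number from compound 2 to compound 4 (0.12 log units; within the scatter) and a 1.3-fold higher number from compound 1 to compound 4 (0.12 log units; within the scatter) leave piperidin-1-yl within the scatter of both those groups, so the assay does not tell these three different groups apart. Among the four compounds, the only separation at this position is between hydroxy and the three larger groups.

The data shown offer no measurement that accounts for this separation. From the compounds shown here alone, it remains open whether a smaller group such as methoxy or dimethylamino would read like compound 3 or like the three larger groups.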